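A Second Chloro Swap on the Methoxy Series

The compounds below may be only part of what the source reports. "The series", "measured", "known", "first", "only" and "open" are said of these compounds alone.

Of the compounds shown here, three sharing one core have been measured in a functional assay on Malme-3M cells (Homo sapiens) for inhibition, read by sulforhodamine B assay, with a stated time of 48 h, tested at 1 uM; on this read-out higher numbers stand for a weaker effect at the one concentration tested and lower numbers for a stronger effect. Compound 1 `O=C(Nc1cccc(-n2cc(-c3ccncc3)c(-c3cc(O)cc(Cl)c3)n2)c1)Nc1ccc(Cl)c(C(F)(F)F)c1` gives 94%. Compound 2 `O=C(Nc1cccc(-n2cc(-c3ccncc3)c(-c3cc(O)cc(Cl)c3)n2)c1)Nc1ccc(Cl)c(Cl)c1` gives 76%, and compound 3 `COc1cc(Cl)cc(-c2nn(-c3cccc(NC(=O)Nc4ccc(Cl)c(C(F)(F)F)c4)c3)cc2-c2ccncc2)c1` gives 67%. Compound 3 therefore carries the lowest of the three numbers, though its gap to compound 2 lies within the usual scatter, while its gap to compound 1 lies beyond it.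

Compound 4 `COc1cc(Cl)cc(-c2nn(-c3cccc(NC(=O)Nc4ccc(Cl)c(Cl)c4)c3)cc2-c2ccncc2)c1` is the next compound, and it differs from compound 3 in one place: chloro in place of trifluoromethyl on an aromatic carbon

The same change has been measured once already, on the hydroxyl-bearing pair, where it gave a number 18 percentage points lower from compound 1 to compound 2 (beyond the scatter). The other measured step, a number 27 percentage points lower from compound 1 to compound 3 (beyond the scatter), leads to compound 3 itself and so sets the starting point. If the chloro-for-trifluoromethyl exchange behaves on compound 3 as it did from compound 1 to compound 2, a modest drop beyond the scatter is expected, giving a step of a number 16 percentage points lower from compound 3 to compound 4 (beyond the scatter). Compound 4 is thus estimated to give 51%, with a range from 36% to 68%.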

Compound 4, a percentage reported as activity, at one concentration (the size of the read-out at that concentration, not a potency): 77%
The estimate for compound 4 lay 26 percentage points below the measured number; the measured number lies above the stated range.
By their numbers in this assay, from the lowest: compounds 3, 2 and 4 (each within the scatter of the next); then compound 1.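

In this assay, the exchange of trifluoromethyl for chloro, on the aromatic carbon ortho to a chloro group, gives a number 10 percentage points higher from compound 3 to compound 4 (within the scatter) when the oxygen carries a methyl. The effect of this change therefore depends on what sits elsewhere in the molecule, and it differs between the hydroxyl and methoxy compounds: the same change on two cores in this assay, a number 18 percentage points lower (beyond the scatter) from compound 1 to compound 2 and a number 10 percentage points higher (within the scatter) from compound 3 to compound 4, 28 percentage points apart, beyond the scatter of two such steps. Methylating the oxygen likewise gives a number 1 percentage points higher from compound 2 to compound 4 (within the scatter) with 3,4-dichlorophenyl in place, so the two changes do not simply add up: the same change on two cores in this assay, a number 27 percentage points lower (beyond the scatter) from compound 1 to compound 3 and a number 1 percentage points higher (within the scatter) from compound 2 to compound 4, 28 percentage points apart, beyond the scatter of two such steps.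

As far as these compounds go, how a methyl or a nitrile on this carbon, or an amine in place of the hydroxyl, would behave on these cores stays open. From the compounds shown here alone, all four numbers come from one concentration, so they show only the size of the effect at that concentration, and how the effect would change at other concentrations stays open.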